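Replacing Nitro with Methyl: What Should Compound 4 Do?

A few compounds are considered here, and "the series" means these few. Any claim that something is new, unique, unknown or untested is made for them only; others in the source may bear on it.

Measured in a functional assay on BGC-823 cells (Homo sapiens) for cytotoxicity, read by MTT assay, with a stated time of 48 h; on this read-out lower numbers stand for stronger inhibition and higher numbers for weaker inhibition:
- compound 1 `NNC(=O)CSc1nnc(-c2ccncc2)o1`: 3260 nM
- compound 2 `O=C(CSc1nnc(-c2ccncc2)o1)N/N=C/c1ccc(Br)cc1`: 24500 nM
- compound 3 `O=C(CSc1nnc(-c2ccncc2)o1)N/N=C/c1ccc([N+](=O)[O-])cc1`: 31500 nM

Compound 3 and compound 2 together form the high end of these numbers, and the two cannot be told apart. Compound 1 stands clearly lower than both.

Compound 4 `Cc1ccc(/C=N/NC(=O)CSc2nnc(-c3ccncc3)o2)cc1` has not been measured yet. It differs from compound 3 in one place: methyl in place of nitro on an aromatic carbon. In words, this is methyl in place of nitro on an aromatic carbon, para to a large group.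

Going by the values given here, only one measured step bears on this change. It reads a 1.3-fold higher number from compound 2 to compound 3 (0.11 log units; within the scatter), and it is nitro in place of bromo on an aromatic carbon. Among the compounds with values here, that single swap stayed within the scatter, though it is thin evidence, and no methyl compound has been measured here. The expectation in this assay is therefore no step beyond the scatter, and so no clear direction. The expected size is a 1.3-fold lower number from compound 3 to compound 4 (0.10 log units; within the scatter). For compound 4 the estimated value is 25000 nM, with an expected range from 11000 nM to 55000 nM.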

Compound 4, half-maximal inhibitory concentration: 21800 nM
Beside the measured number, compound 4's estimate is 1.1-fold (0.06 log units) above it; the measured number falls inside the stated range.
By their numbers in this assay, from the lowest: compound 1; then compounds 4, 2 and 3 (each within the scatter of the next).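

In this assay, the change from 4-nitrophenyl to 4-methylphenyl gives a 1.4-fold lower number from compound 3 to compound 4 (0.16 log units; within the scatter), and replacing bromo with methyl gives a 1.1-fold lower number from compound 2 to compound 4 (0.05 log units; within the scatter). Bromo, nitro and methyl on this aromatic carbon, para to a large group, therefore give numbers that cannot be told apart, where before only the comparison of bromo with nitro was available. Compound 4 also shows that, across this pair, going from nitro to methyl lowers the heavy-atom count from 3 to 1 and removes the hydrogen-bond acceptors of the group without a step beyond the scatter, although no measurement at hand explains why these compounds read alike.

Going by these compounds alone, this flat picture rests on only three groups at one place, so it should not be stretched into a general rule for the ring. Still open, going by these compounds, is whether an amine, a carboxylic acid or a longer chain at this same place would stay with these numbers or move the result clearly in either direction.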